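This account rests on a few compounds, and the source may have more. Where it says the series, first, only, none or still open, it means among the compounds named here.

Of the compounds shown here, three that share one core have been tested in a functional assay on DU-145 cells (Homo sapiens) for cytotoxicity, read by MTT assay; a higher number here means a weaker inhibitor, a lower number a stronger inhibitor. Compound 1 `CCCCCCCCC1CC1CCCCCCCC(=O)OC[C@H](CO[C@@H]1O[C@H](CO)[C@@H](O)[C@H](O)[C@H]1O)OC(=O)CCCCCCCC1CC1CCCCCCCC` gives 210000 nM, and compound 2 `C=CCCCCCCCCC(=O)OC[C@H](CO[C@@H]1O[C@H](CO)[C@@H](O)[C@H](O)[C@H]1O)OC(=O)CCCCCCCCC=C` gives 119000 nM, so these two lie within the usual scatter of each other. Compound 3 `CCCCCCCCCCCC(=O)OC[C@H](CO[C@@H]1O[C@H](CO)[C@@H](O)[C@H](O)[C@H]1O)OC(=O)CCCCCCCCCCC` gives 54900 nM, clearly lower than the number for compound 1, which leaves compound 1 at the high end of this small set. Compound 4 `CCCCCCCC/C=C\CCCCCCCC(=O)O[C@H](COC(=O)CCCCCCCC1CC1CCCCCCCC)CO[C@@H]1O[C@H](CO)[C@@H](O)[C@H](O)[C@H]1O` has not been measured yet. Its change from compound 1 is dec-1-en-1-yl in place of 2-octylcyclopropyl on a saturated chain carbon, seven bonds along the chain from a carbonyl carbon. Among the compounds with values here, no measured pair shows this change alone, so in this assay only a small move towards a lower number is expected, possibly none beyond the scatter. The estimated step is a 1.4-fold lower number from compound 1 to compound 4 (0.15 log units; within the scatter). For compound 4 the expected value is 150000 nM, with an estimated range from 70000 nM to 300000 nM.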

Compound 4, half-maximal inhibitory concentration: 38900 nM
The estimate for compound 4 lay 3.9-fold (0.59 log units) above the measured number; the measured number lies below the stated range.
By their numbers in this assay, from the lowest: compounds 4 and 3 (each within the scatter of the next); then compounds 2 and 1 (each within the scatter of the next).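

Putting dec-1-en-1-yl in place of 2-octylcyclopropyl on a saturated chain carbon, seven bonds along the chain from a carbonyl carbon, gives a 5.4-fold lower number from compound 1 to compound 4 (0.73 log units; beyond the scatter) in this assay, a step beyond the scatter. So this place responds to the change, even though the other chain of compound 4 still carries its 2-octylcyclopropyl. Nothing available explains the shift. Going by these compounds, whether the ring's loss or the double bond's arrival matters more stays open. So does the effect of dec-1-en-1-yl on both chains, or of a longer chain ending in an amine.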